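This account rests on a few compounds, and the source may have more. Where it says the series, first, only, none or still open, it means among the compounds named here.

Three compounds share one core and differ only in the groups hung on it. Compound 1 `CCNC(=O)[C@H]1O[C@@H](n2cnc3c(NOC)nc(I)nc32)[C@H](O)[C@@H]1O` carries an iodo group; in an assay on CHO cells for displacement of a labelled ligand from adenosine receptor A3 (Homo sapiens) (on this read-out higher numbers stand for weaker inhibition and lower numbers for stronger inhibition), compound 1 gives 2.8 nM. Compound 2 `CNC(=O)[C@H]1O[C@@H](n2cnc3c(NOC)nc(C#Cc4ccc(F)cc4)nc32)[C@H](O)[C@@H]1O` gives 1.9 nM in this assay, and compound 3 `CCNC(=O)[C@H]1O[C@@H](n2cnc3c(NOC)nc(C#Cc4ccc(C)cc4)nc32)[C@H](O)[C@@H]1O` gives 6.8 nM. On these numbers compound 3 stands highest, that is, it is the weakest of the three, with compound 1 as its nearest neighbour and compound 2 furthest away. Among the compounds with values here, the one step measured between close pairs is a 2.4-fold higher number from compound 1 to compound 3 (0.39 log units; beyond the scatter), the exchange of iodo for 2-(4-methylphenyl)ethynyl.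

Compound 4 `CCNC(=O)[C@H]1O[C@@H](n2cnc3c(NOC)nc(C#Cc4ccc(F)cc4)nc32)[C@H](O)[C@@H]1O` differs from compound 3 in one place: fluoro in place of methyl on an aromatic carbon. Within the data shown here, no measured step covers this exchange; the step of a 2.4-fold higher number from compound 1 to compound 3 (0.39 log units; beyond the scatter) concerns a different position and says nothing about methyl against fluoro. Compound 2 does carry the same 2-(4-fluorophenyl)ethynyl group, yet with a different amide, so its number and that of compound 3 can only be set side by side: compound 2 gives 1.9 nM, compound 3 gives 6.8 nM. On that comparison a modest move towards a lower number, a 1.9-fold lower number from compound 3 to compound 4 (0.29 log units; within the scatter), is expected. Compound 4 is therefore estimated at 3.5 nM, within 1.2 nM to 10 nM.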

Compound 4, inhibition constant: 3.2 nM
Compound 4: the middle estimate sits 1.1-fold (0.04 log units) above what was measured, within the range that was stated.
By their numbers in this assay, from the lowest: compounds 2, 1 and 4 (each within the scatter of the next); then compound 3.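

The a 2.1-fold lower number from compound 3 to compound 4 (0.33 log units; beyond the scatter) shows that, with the amide held the same, the group on this aromatic carbon, para to a large group, can shift the number in this assay. The a 1.1-fold higher number from compound 1 to compound 4 (0.06 log units; within the scatter) lies within the scatter, so the long 2-(4-fluorophenyl)ethynyl group cannot be told apart from iodo, and the rise seen with 2-(4-methylphenyl)ethynyl does not come from every ethynyl group placed there; likewise, a 1.7-fold higher number from compound 2 to compound 4 (0.23 log units; within the scatter) lies within the scatter, so the added methyl on the amide chain shows no clear effect here. Nothing available explains why fluoro and methyl differ at this place.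

As far as these compounds go, how a chloro group, a methoxy group or an amine would compare at this place stays open. So does whether fluoro in place of methyl would give a step of similar size with the amide of compound 2.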